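The source may report more compounds than this note shows. Statements on the series, on what has been measured and on what is new or still open speak of the compounds shown alone.

In a functional assay on NTUB1 cells (Homo sapiens) for cytotoxicity, read by MTT assay, with a stated time of 72 h (a lower number here means a stronger inhibitor, a higher number a weaker inhibitor), compound 1 (`CNC(=O)c1ccc(/C=C/C(=O)c2cc(OC)ccc2OC)cc1`) gives 2200 nM and compound 2 (`CCNC(=O)c1ccc(/C=C/C(=O)c2cc(OC)ccc2OC)cc1`) gives 3760 nM, so these two values lie within the scatter of each other. Compound 3 (`CCCNC(=O)c1ccc(/C=C/C(=O)c2cc(OC)ccc2OC)cc1`) differs from compound 2 by methyl in place of hydrogen on a saturated chain carbon, two bonds along the chain from an amide-type nitrogen, which reads as ethylamino to propylamino. For the measured compounds named here, the only measured step that bears on this is a 1.7-fold higher number from compound 1 to compound 2 (0.23 log units; within the scatter), the same kind of exchange one carbon nearer the amide-type nitrogen. A single step within the scatter gives thin support for any trend, so no change beyond the scatter is expected. The expected step is small, a 1.2-fold higher number from compound 2 to compound 3 (0.08 log units; within the scatter). For compound 3 the estimated value is 4500 nM, with an expected range from 2000 nM to 9000 nM.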

Compound 3, half-maximal inhibitory concentration: 2260 nM
Compound 3: the middle estimate sits 2.0-fold (0.30 log units) above what was measured, within the range that was stated.
By their numbers in this assay, from the lowest: compounds 1, 3 and 2 (each within the scatter of the next).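

In this assay, the move from ethylamino to propylamino gives a 1.7-fold lower number from compound 2 to compound 3 (0.22 log units; within the scatter), while the same kind of exchange one carbon nearer the amide-type nitrogen gave a 1.7-fold higher number from compound 1 to compound 2 (0.23 log units; within the scatter), so the two steps point in opposite printed directions and neither lies beyond the scatter. Taken as one exchange, ethyl in place of hydrogen on the saturated chain carbon bound to the amide-type nitrogen gives a 1.0-fold higher number from compound 1 to compound 3 (0.01 log units; within the scatter), which places all three compounds within the scatter of each other and shows no trend with chain length across this short run. No measured evidence accounts for these small differences.

On these data alone, whether a longer chain or a branched chain at this position would give a step beyond the scatter remains open. The same holds for an amine or a carboxylic acid at the end of the chain.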